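A hydroxy group on the pyridyl ring of compound 3

The source may hold more compounds than are shown below. What is called first, only, known or untested is meant among the compounds shown, and "the series" means these compounds.

Three compounds share one core and differ only in the aryl group attached to it. In an in vitro functional assay on HEK285-7 cells for antagonist activity at prostaglandin D2 receptor 2 (Homo sapiens), read by BRET and beta-arrestin recruitment (on this read-out higher numbers stand for weaker inhibition and lower numbers for stronger inhibition), compound 1 `O=C(O)Cc1sc(C(c2ccc(F)cc2)c2ccc(F)cc2)nc1-c1ccc(Cl)cc1` gives 180 nM, and compound 2 `N#Cc1cc(-c2nc(C(c3ccc(F)cc3)c3ccc(F)cc3)sc2CC(=O)O)ccc1F` gives 520 nM. Compound 3 `O=C(O)Cc1sc(C(c2ccc(F)cc2)c2ccc(F)cc2)nc1-c1ccncc1` stands lowest of the three in this assay with 40 nM; the steps leading to it are a 4.5-fold lower number from compound 1 to compound 3 (0.65 log units; beyond the scatter) and a 13-fold lower number from compound 2 to compound 3 (1.11 log units; beyond the scatter), while the remaining pair shows a 2.9-fold higher number from compound 1 to compound 2 (0.46 log units; beyond the scatter).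

Compound 4 `O=C(O)Cc1sc(C(c2ccc(F)cc2)c2ccc(F)cc2)nc1-c1ccnc(O)c1` keeps the pyridin-4-yl of compound 3 and differs from it in one place: hydroxy in place of hydrogen on an aromatic carbon. Going by the values given here, none of the measured steps touches this ring with an added group; all three exchange the whole aryl group. The measured steps therefore offer no direct guide, and the expected step for compound 4 is a modest one, a 1.3-fold higher number from compound 3 to compound 4 (0.10 log units; within the scatter), in either direction and possibly within the scatter. Compound 4 is estimated to give 50 nM in this assay, within a range from 20 nM to 150 nM.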

Compound 4, half-maximal inhibitory concentration: 890 nM
For compound 4 the middle estimate is 18-fold (1.25 log units) below the measured one; measured number above the stated range.
By their numbers in this assay, from the lowest: compound 3; then compound 1; then compounds 2 and 4 (each within the scatter of the next).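

In this assay, the pyridin-4-yl ring of compound 3 proves sensitive to a single added group: hydroxy in place of hydrogen, next to the ring nitrogen, gives a large step (a 22-fold higher number from compound 3 to compound 4 (1.35 log units; beyond the scatter)). The edge that pyridin-4-yl held over both substituted phenyl groups does not survive this change, as 2-hydroxypyridin-4-yl compares unfavourably with 4-chlorophenyl (a 4.9-fold higher number from compound 1 to compound 4 (0.69 log units; beyond the scatter)) and cannot be separated from 3-cyano-4-fluorophenyl (a 1.7-fold higher number from compound 2 to compound 4 (0.23 log units; within the scatter)). Nothing available here accounts for the size of this step.

Going by these compounds, whether the loss belongs to hydroxy itself or to this place on the ring remains open. A methoxy or an amino group on the same carbon, or a hydroxy group elsewhere on the pyridine ring, would bear on that question.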